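Chloro in place of methyl on the anilide ring

The source may report more compounds than this note shows. Statements on the series, on what has been measured and on what is new or still open speak of the compounds shown alone.

The study concerns a set of thiosemicarbazone derivatives sharing one core, examined in a functional assay on HeLa cells (Homo sapiens) for inhibition, read by cell counting, with a stated time of 96 h; a higher number here means a weaker inhibitor, a lower number a stronger inhibitor. Compound 2 `CCN(CC)CN1C(=O)/C(=N/NC(=S)Nc2ccccc2)c2ccccc21` gives 8300 nM in this assay. Compound 3 `CCN(CC)CN1C(=O)/C(=N/NC(=S)Nc2ccc(C)cc2)c2ccccc21` gives 12000 nM in this assay. Compound 3 thus holds the highest number of the two measured in this assay, but its nearest neighbour is compound 2, and the step of a 1.4-fold higher number from compound 2 to compound 3 (0.16 log units; within the scatter) lies within the scatter, so the two cannot be ordered. Compound 1 `CCN(CC)CN1C(=O)/C(=N/NC(=S)Nc2ccc(Cl)cc2)c2cc(Cl)ccc21` was reported only as a limit of this assay, > 125000 nM, as the evidence the limit of > 125000 nM in this assay, at which 1 of the 3 values shown sits, states.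

Compound 4 `CCN(CC)CN1C(=O)/C(=N/NC(=S)Nc2ccc(Cl)cc2)c2ccccc21` is not yet measured. It differs from compound 3 as follows: chloro in place of methyl on an aromatic carbon. For the measured compounds named here, no measured step covers this exchange of chloro for methyl; the only step at hand, a 1.4-fold higher number from compound 2 to compound 3 (0.16 log units; within the scatter), concerns the methyl itself and stayed within the scatter. Compound 1 carries the same 4-chlorophenyl group together with a further chloro on the core, so its limit is only a loose pointer. The expectation for compound 4 is therefore a small change, if any, most likely toward a higher number, with the step of a 1.7-fold higher number from compound 3 to compound 4 (0.22 log units; within the scatter) estimated. Compound 4 is expected to give about 20000 nM in this assay, with a range from 6000 nM to 80000 nM.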

Compound 4, half-maximal inhibitory concentration: 7600 nM
Beside the measured number, compound 4's estimate is 2.6-fold (0.42 log units) above it, and the stated range covers the measured number.
By their numbers in this assay, from the lowest: compounds 4, 2 and 3 (each within the scatter of the next). At a limit, above all of these: compound 1.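

With a 1.6-fold lower number from compound 3 to compound 4 (0.20 log units; within the scatter) and a 1.1-fold lower number from compound 2 to compound 4 (0.04 log units; within the scatter), hydrogen, methyl and chloro on this aromatic carbon cannot be ordered in this assay. The earlier compounds had shown this only for methyl against hydrogen, whereas compound 4 extends it to a chloro, so among compounds 2, 3 and 4 the exchange at this place leaves the number within the scatter. Compound 1 differs from compound 4 only by the further chloro on the core, and an at least 16-fold lower number from compound 1 to compound 4 (1.21 log units; beyond the scatter) places the large difference at that core position rather than on the 4-chlorophenyl group, although the value of compound 1 is a limit and the true size of the step stays unknown: the limit of > 125000 nM in this assay, at which 1 of the 4 values shown sits.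

The compounds shown leave open whether a methoxy group, an amine or a carboxylic acid at this place on the ring would also stay within the scatter of compounds 2, 3 and 4. They also leave open whether the chloro on the core has the same large effect when the ring carries hydrogen or methyl, or when a bromo stands in its place on the core.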